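Chloro in place of fluoro: what to expect

A few compounds are considered here, and "the series" means these few. Any claim that something is new, unique, unknown or untested is made for them only; others in the source may bear on it.

Compound 1 `COc1cc(NC(C)CCCNC(=O)/C(C)=C/c2ccccc2)c2ncccc2c1`: > 100 ug/mL (a limit of the assay)
Compound 2 `COc1cc(NC(C)CCCNC(=O)/C=C/c2ccc(Cl)cc2)c2ncccc2c1`: 7.1 ug/mL
Compound 3 `COc1cc(NC(C)CCCNC(=O)Nc2cccc(F)c2)c2ncccc2c1`: 9.18 ug/mL

In an ADME assay on L6 cells (Rattus norvegicus) for cytotoxicity, read by resazurin assay, with a stated time of 70 h (on this read-out higher numbers stand for weaker inhibition and lower numbers for stronger inhibition), compound 3, at 9.18 ug/mL, stands level with compound 2, since a 1.3-fold higher number from compound 2 to compound 3 (0.11 log units; within the scatter) stays within the scatter. Compound 1 gives only a limit.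

Compound 4 `COc1cc(NC(C)CCCNC(=O)Nc2cccc(Cl)c2)c2ncccc2c1` differs from compound 3 by chloro in place of fluoro on an aromatic carbon. Among the compounds with values here, no measured step makes this swap. The large steps, an at least 14-fold lower number from compound 1 to compound 2 (1.14 log units; beyond the scatter) and an at least 10-fold lower number from compound 1 to compound 3 (1.03 log units; beyond the scatter), both remove 1-methyl-2-phenylethenyl, a group absent here. The nearest guide is a 1.3-fold higher number from compound 2 to compound 3 (0.11 log units; within the scatter), a far bigger change that still moved little. The expected step, a 1.2-fold lower number from compound 3 to compound 4 (0.09 log units; within the scatter), therefore stays within the scatter. For compound 4 the estimated value is 7.5 ug/mL, with an expected range of 3 ug/mL to 19 ug/mL.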

Compound 4, half-maximal inhibitory concentration: 10 ug/mL
Beside the measured number, compound 4's estimate is 1.3-fold (0.12 log units) below it; the range from low to high includes it.
By their numbers in this assay, from the lowest: compounds 2, 3 and 4 (each within the scatter of the next). At a limit, above all of these: compound 1.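

Chloro in place of fluoro on this aromatic carbon gives a 1.1-fold higher number from compound 3 to compound 4 (0.04 log units; within the scatter), so in this pair the swap of one halogen for the other brings no readable change in this assay. Replacing the 2-(4-chlorophenyl)ethenyl group with (3-chlorophenyl)amino likewise gives a 1.4-fold higher number from compound 2 to compound 4 (0.15 log units; within the scatter), which keeps the two compounds level. The remaining step, an at least 10-fold lower number from compound 1 to compound 4 (1.00 log units; beyond the scatter), rests on a limit of the assay and is only a bound: the limit of > 100 ug/mL in this assay, at which 1 of the 4 values shown sits.

The compounds shown leave open whether a group other than a halogen on this aromatic carbon, such as an amine or a carboxylic acid, would keep the number level. They also leave open whether chloro and fluoro would stay level on the ethenyl-linked compounds.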